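Swapping a pyridyl for a phenyl on a weak cytotoxic scaffold

A few compounds are considered here, and "the series" means these few. Any claim that something is new, unique, unknown or untested is made for them only; others in the source may bear on it.

Measured compounds:
- compound 1, `Oc1ccc(-c2cc(-c3ccccn3)nc(-c3ccccc3Cl)c2)cc1`: "not determined" (no result reported)
- compound 2, `Oc1ccc(-c2cc(-c3cccc(Cl)c3)nc(-c3ccccn3)c2)cc1`: 27900 nM
- compound 3, `Oc1cccc(-c2cc(-c3cccc(Cl)c3)nc(-c3ccccn3)c2)c1`: "not determined" (no result reported)

In a functional assay on T47D cells (Homo sapiens) for cytotoxicity, read by CCK-8 assay and cell counting, with a stated time of 2 days (on this read-out lower numbers stand for stronger inhibition and higher numbers for weaker inhibition), compound 2 gives 27900 nM, which marks it as a weak inhibitor of cell growth. Within the data shown here, compound 2 is the only one of the three with a reported number; for compound 1 and compound 3 no result exists, so compound 2 cannot be ranked against them, and there is no measured pair of neighbours from which the weight of any single change could be read.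

Compound 4, `Oc1ccc(-c2cc(-c3ccccc3)nc(-c3cccc(Cl)c3)c2)cc1`, differs from compound 2 in one place: phenyl in place of pyridin-2-yl on an aromatic carbon. The change sits on an aromatic carbon of the shared core, next to the ring nitrogen, meta to a 3-chlorophenyl group and meta to a 4-hydroxyphenyl group.

Among the measured compounds shown here, with no measured step to lean on, the expectation for compound 4 is cautious: a step from compound 2 that stays within the usual scatter, or at most drifts toward weaker inhibition, since the reference value of compound 2 at 27900 nM already lies at the weak end. The estimated step of a 1.3-fold higher number from compound 2 to compound 4 (0.10 log units; within the scatter) is therefore small. Compound 4 is expected to give about 35000 nM in this assay, within a range from 9000 nM to 140000 nM.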

Compound 4, half-maximal inhibitory concentration: 4790 nM
Compound 4: middle estimate off by 7.3-fold (0.86 log units), on the high side; the whole stated range lies above it.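

In this assay, placing phenyl instead of pyridin-2-yl on this aromatic carbon, next to the ring nitrogen, gives a 5.8-fold lower number from compound 2 to compound 4 (0.77 log units; beyond the scatter) and so moves the result toward stronger inhibition, which shows that this position responds to the change. The two groups have the same number of heavy atoms and both are six-membered aromatic rings; the pyridin-2-yl holds one ring nitrogen, counted as a hydrogen-bond acceptor, while the phenyl is carbon only, so exchanging a single ring atom is enough to carry the step beyond the usual scatter. Nothing in the data explains why this exchange has such an effect.

Going by these compounds, this is one step at one position, so it sets no trend, and whether the same carbon would accept a larger substituted ring, such as a 4-methoxyphenyl, or a non-aromatic group, such as a morpholine or a short amine chain, stays open. The two numbers also give no separate reading of what the hydroxyl or the chlorine contributes on the shared core.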